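The compounds below may be only part of what the source reports. "The series", "measured", "known", "first", "only" and "open" are said of these compounds alone.

Compound 1, `COc1ccc(C(=O)N2CCN(CC(=O)N3CCN(CCCc4c[nH]c5ccc(F)cc45)CC3)CC2)cc1`, in an ADME assay on SH-SY5Y cells (Homo sapiens) for cytotoxicity, read by MTT assay, with a stated time of 72 h (a lower number here means a stronger inhibitor, a higher number a weaker inhibitor), gives 161000 nM.
Compound 2, `O=C(CN1CCN(C(=O)c2ccc(Br)cc2)CC1)N1CCN(CCCc2c[nH]c3ccc(F)cc23)CC1`, in this assay gives 47400 nM.
Compound 3, `COc1cccc(C(=O)N2CCN(CC(=O)N3CCN(CCCc4c[nH]c5ccc(OC)cc45)CC3)CC2)c1`, in this assay gives only a limit, > 200000 nM.

Compound 2 differs from compound 1 in one place: bromo in place of methoxy on an aromatic carbon. That change gave a 3.4-fold lower number from compound 1 to compound 2 (0.53 log units; beyond the scatter). Compound 3 sits at the limit of > 200000 nM in this assay, at which 1 of the 3 values shown sits, so for compound 3 no number is known, only that limit.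

Compound 4, `COc1ccc2[nH]cc(CCCN3CCN(C(=O)CN4CCN(C(=O)c5cccc(Br)c5)CC4)CC3)c2c1`, has not been measured yet. It differs from compound 3 in one place: bromo in place of methoxy on an aromatic carbon. The difference between the core of compound 3 and the core of compound 1 is not broken down here. The change from compound 3 to compound 4 is the same kind of change as that from compound 1 to compound 2, but not the same: in compound 2 the bromo stands para to a large group, in compound 4 it stands meta to a large group.

Resting on the step of a 3.4-fold lower number from compound 1 to compound 2 (0.53 log units; beyond the scatter), a step of similar size is expected from compound 3 to compound 4, an at least 1.6-fold lower number from compound 3 to compound 4 (0.22 log units; that floor lies within the scatter). Because the value of compound 3 is only a limit, > 200000 nM, the starting point is uncertain, so the expectation for compound 4 is wide. Compound 4 is expected to give about 120000 nM in this assay, with a likely range from 40000 nM to 400000 nM.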

Compound 4, half-maximal inhibitory concentration: 105000 nM
Beside the measured number, compound 4's estimate is 1.1-fold (0.06 log units) above it; measured number inside the range.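

Replacing methoxy with bromo on the benzoyl-side aromatic ring again comes with a lower number in this assay, here an at least 1.9-fold lower number from compound 3 to compound 4 (0.27 log units; that floor lies within the scatter), so the second core does not go against the direction seen on the first, although the smallest step the data allow does not clear the usual scatter on its own. Placed side by side, the two results read as follows: the same change on two cores in this assay, a 3.4-fold lower number (0.53 log units; beyond the scatter) from compound 1 to compound 2 and an at least 1.9-fold lower number (0.27 log units; that floor lies within the scatter) from compound 3 to compound 4; the limit leaves it open whether they differ. Going by these compounds alone, the value of compound 3, > 200000 nM, is a limit and not a number, so this pair gives no exact size for the step, and two pairs on two cores show only that the change can be carried across in this one assay, not that it has a fixed size or that it would hold on every core.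

As far as these compounds go, only methoxy and bromo appear in this comparison, so it stays open how other groups at the same place, such as an amine or a carboxylic acid, would read in this assay. From the compounds shown here alone, it also stays open whether the change from methoxy to bromo would give a step of similar size on a core with a longer chain.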